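The compounds below may be only part of what the source reports. "The series", "measured", "known", "first", "only" and "open" are said of these compounds alone.

In a toxicity assay on PH5CH cells (Homo sapiens) for cytotoxicity, read by MTT assay, with a stated time of 72 h (a lower number here means that less compound is tolerated, a higher number that more compound is tolerated), compound 1 `CCOCc1sc(NCc2ncccn2)nc1-c1ccccn1` gives 50000 nM and compound 2 `CCOC(=O)c1sc(Nc2ncccn2)nc1-c1cnccn1` gives 50000 nM so compound 2 stands level with compound 1. Compound 3 `CCOC(=O)c1sc(Nc2ncccn2)nc1-c1ccncn1` differs from compound 2 in a single group pyrimidin-4-yl in place of pyrazin-2-yl on an aromatic carbon with pyrimidin-4-yl in place of pyrazin-2-yl on an aromatic carbon. For the measured compounds named here, no measured pair of compounds differs in just one place, so the data offer no direct guide to this change. In this assay the expected step is no change at the digits printed from compound 2 to compound 3 (within the scatter) and it should stay within the scatter, with no favoured direction. Compound 3 is estimated at 50000 nM and expected to fall between 20000 nM and 100000 nM.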

Compound 3, half-maximal cytotoxic concentration: 40000 nM
The estimate for compound 3 lay 1.3-fold (0.10 log units) above the measured number, within the range that was stated.
By their numbers in this assay, from the lowest: compounds 3, 1 and 2 (each within the scatter of the next).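

For the compounds shown here, changing pyrazin-2-yl to pyrimidin-4-yl on the aromatic carbon next to the ring nitrogen gives a 1.3-fold lower number from compound 2 to compound 3 (0.10 log units; within the scatter) in this assay, the only single-place step available here. At this position, then, these two rings, which have the same atoms joined differently, are not told apart by this read-out. No measurement shown here speaks to why this is so.

Still open, from the compounds shown here alone, is whether a group of another kind at this position, such as a phenyl ring or an amine, would shift the number. Also open, going by these compounds, is what a carboxylic acid would do in place of the ethoxycarbonyl group.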